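The compounds below may be only part of what the source reports. "The series", "measured", "known", "first", "only" and "open" are said of these compounds alone.

Measured compounds:
- compound 1, `CCN(CC)c1cc2[nH]c(C3CCCCC3)nc2cc1NC(=O)c1ccc(N(C)C)cc1`: "not determined" (no result reported)
- compound 2, `CCCCCC(=O)Nc1cc2nc(C3CCCCC3)[nH]c2cc1N(CC)CC`: "not determined" (no result reported)
- compound 3, `CCN(CC)c1cc2[nH]c(C3CCCCC3)nc2cc1NC(=O)c1ccc(OC(F)F)cc1`: > 100 ug/mL

The three compounds share one core and were examined in an ADME assay on Vero cells (Chlorocebus sabaeus) for cytotoxicity, read by resazurin assay, with a stated time of 3 days; on this read-out lower numbers stand for stronger inhibition and higher numbers for weaker inhibition. For compound 1 and for compound 2 no result is recorded, so in this assay the only entry is that of compound 3. For compound 3 this assay gives > 100 ug/mL, which is a limit of the assay and not a number. Among the three entries, compound 3 is the one that sits at the limit of > 100 ug/mL in this assay, at which 1 of the 3 values shown sits, and nothing further can be said about where it stands relative to the others, since those are without a number.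

Compound 4, `CCCOCC(=O)Nc1cc2nc(C3CCCCC3)[nH]c2cc1N(CC)CC`, is the next compound to be measured in this assay. It differs from compound 3 in one place: propoxymethyl in place of 4-(difluoromethoxy)phenyl on a carbonyl carbon. Among the measured compounds shown here, no measured pair with a comparable change exists here, so there is no step to lean on. Since compound 3 itself only reached a limit, the expectation is that the change from compound 3 to compound 4 brings no shift beyond the scatter, and the step is estimated as a step that the limit leaves unreadable from compound 3 to compound 4. Compound 4 is therefore expected to come in around 120 ug/mL, within a range from 60 ug/mL to 300 ug/mL, with a good chance that once again only a limit is reported.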

Compound 4, half-maximal inhibitory concentration: > 100 ug/mL
Compound 4: a limit, no number; the forecaster's own chance of this, stated with the estimate: 75%; the middle value lies beyond the limit too.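

In this assay compound 3 and compound 4 each give a limit and not a number, so no step can be read between them: the limit of > 100 ug/mL in this assay, at which 2 of the 4 values shown sit. The compounds shown leave open whether propoxymethyl in place of 4-(difluoromethoxy)phenyl on a carbonyl carbon makes any difference in this assay.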